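Swapping the Ester for a Dimethylamide

The compounds below may be only part of what the source reports. "The series", "measured", "known", "first", "only" and "open" are said of these compounds alone.

Three compounds share one core. Compound 1 `COc1ccc2c(c1)OC(c1cc(OC)c(OC)c(OC)c1)C(C(=O)N1CCCCC1)=C2` carries a piperidin-1-yl on its carbonyl carbon, and in a functional assay for inhibition of nuclear factor NF-kappa-B complex (Homo sapiens) (a higher number here means a weaker inhibitor, a lower number a stronger inhibitor), compound 1 gives only a limit, > 50000 nM, as recorded by the limit of > 50000 nM in this assay, at which 1 of the 3 values shown sits. Compound 2 `COc1ccc2c(c1)OC(c1cc(OC)c(OC)c(OC)c1)C(C=O)=C2` gives 13500 nM in this assay, and compound 3 `CCOC(=O)C1=Cc2ccc(OC)cc2OC1c1cc(OC)c(OC)c(OC)c1` gives 25000 nM, standing alongside compound 2 as a 1.9-fold higher number from compound 2 to compound 3 (0.27 log units; within the scatter) shows. Compound 4 `COc1ccc2c(c1)OC(c1cc(OC)c(OC)c(OC)c1)C(C(=O)N(C)C)=C2` differs from compound 3 by dimethylamino in place of ethoxy on a carbonyl carbon, or, read one bond further out, ethoxycarbonyl to dimethylcarbamoyl. The measured step that bears on this is an at least 2.0-fold lower number from compound 1 to compound 3 (0.30 log units; that floor lies within the scatter), the reverse direction of the present change, with an at least 3.7-fold lower number from compound 1 to compound 2 (0.56 log units; beyond the scatter) alongside. Returning to an amide is therefore expected to raise the number, and the change is estimated as a 1.8-fold higher number from compound 3 to compound 4 (0.26 log units; within the scatter). Compound 4 is expected at 45000 nM, with a range from 15000 nM to 150000 nM.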

Compound 4, half-maximal inhibitory concentration: > 50000 nM
Compound 4 ended at the assay's limit (the forecaster's own chance of this, stated with the estimate: 45%); middle value at least 1.1-fold (0.04 log units) away from the limit.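

Compound 4 joins compound 1 at a limit in this assay: the limit of > 50000 nM in this assay, at which 2 of the 4 values shown sit. A weak result on this carbonyl carbon is therefore not confined to the piperidin-1-yl ring, as the open-chain dimethylamino also gives no number, and the step between these two limits cannot be read. With hydrogen in that place the step is an at least 3.7-fold higher number from compound 2 to compound 4 (0.56 log units; beyond the scatter), whereas with ethoxy it is an at least 2.0-fold higher number from compound 3 to compound 4 (0.30 log units; that floor lies within the scatter).

Going by these compounds, how far the two amides lie past the limit stays open, as does whether methylamino or a carboxylic acid here would give a readable value.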